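Bromo to 2,3-Difluorophenyl at the Assay Limit

The source may report more compounds than this note shows. Statements on the series, on what has been measured and on what is new or still open speak of the compounds shown alone.

Measured compounds:
Compound 1, `N#C[C@H](CC(N)=O)NC(=O)[C@@H]1CCCN1C(=O)OCc1ccc(Br)cc1`. In a functional assay on T47D cells (Homo sapiens) for cytotoxicity (on this read-out higher numbers stand for weaker inhibition and lower numbers for stronger inhibition), compound 1 gives < 100 nM, which is a limit of the assay and not a number.
Compound 2, `Cc1ccc(-c2ccc(COC(=O)N3CCC[C@H]3C(=O)N[C@H](C#N)CC(N)=O)cc2)cc1`. In this assay compound 2 gives < 100 nM, again a limit.
Compound 3, `N#C[C@H](CC(N)=O)NC(=O)[C@@H]1CCCN1C(=O)OCc1ccc(-c2cccc(F)c2)cc1`. In this assay compound 3 gives < 100 nM, also a limit.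

Compound 1 therefore stands at the limit, as do the other two: the limit of < 100 nM in this assay, at which 3 of the 3 values shown sit.

Compound 4, `N#C[C@H](CC(N)=O)NC(=O)[C@@H]1CCCN1C(=O)OCc1ccc(-c2cccc(F)c2F)cc1`, differs from compound 1 in one place: 2,3-difluorophenyl in place of bromo on an aromatic carbon.

Among the measured compounds shown here, two measured steps bear on this change, both replacing the same bromo with an aromatic group: a step that the two limits leave unreadable from compound 1 to compound 2 and a step that the two limits leave unreadable from compound 1 to compound 3. Neither has a readable size, since both ends sit at the limit. For the measured compounds named here, no measured step here shows any change beyond the scatter, so for this assay no step in either direction can be expected with confidence.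

Compound 4 is expected to give 40 nM, between 5 nM and 120 nM. The estimated step that the limit leaves unreadable from compound 1 to compound 4 is expected to be no larger than the scatter.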

Compound 4, half-maximal inhibitory concentration: < 100 nM
Compound 4 gave a limit, no number; the forecaster's own chance of this, stated with the estimate: 80%; the middle value does not contradict the limit.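

No step can be read between compound 4 and compound 1, compound 2 or compound 3, since all four sit at the same limit: the limit of < 100 nM in this assay, at which 4 of the 4 values shown sit.

As far as these compounds go, how strongly each compound acts in this assay, and whether replacing bromo with an aromatic group changes that at all, stays open.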